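The compounds below may be only part of what the source reports. "The series", "measured", "known", "first", "only" and "open" are said of these compounds alone.

Compounds measured so far:
Compound 1, `COc1ccc(Cl)cc1N(CC(=O)Nc1cccc2ccccc12)S(=O)(=O)c1ccccc1`, gives 17400 nM
Compound 2, `COc1ccc(Cl)cc1N(CC(=O)Nc1ccccc1)S(=O)(=O)c1ccccc1`, reaches only the limit > 20000 nM
Compound 3, `COc1ccc(Cl)cc1N(CC(=O)NC1CCCCC1)S(=O)(=O)c1ccccc1`, gives 17600 nM

These three compounds share one core and differ only in the group on the amide-type nitrogen. In a functional assay on SH-SY5Y cells (Homo sapiens), read by MTT assay, with a stated time of 24 h (a higher number here means that more compound is needed for the effect, a lower number that less compound is needed), compound 1 has the lowest of the two numbers shown, yet compound 3 sits within the scatter of it, so the two cannot be ranked. For compound 2 the result is a limit of the assay rather than a number, a situation that matches (the limit of > 20000 nM in this assay, at which 1 of the 3 values shown sits).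

Compound 4, `COc1ccc(Cl)cc1N(CC(=O)Nc1ccc([N+](=O)[O-])cc1)S(=O)(=O)c1ccccc1`, has not yet been measured. Its change from compound 1 is 4-nitrophenyl in place of naphthalen-1-yl on an amide-type nitrogen. Going by the values given here, two measured steps bear on this change. Replacing naphthalen-1-yl with phenyl gave an at least 1.1-fold higher number from compound 1 to compound 2 (0.06 log units; that floor lies within the scatter), and replacing it with cyclohexyl gave a 1.0-fold higher number from compound 1 to compound 3 (0.00 log units; within the scatter). Neither step moved the number beyond the scatter, so the group on this nitrogen appears to matter little here, with no compound shown going against that.

For compound 4 the expected step is therefore a 1.1-fold higher number from compound 1 to compound 4 (0.06 log units; within the scatter), essentially none beyond the scatter. Compound 4 is estimated to give 20000 nM, with a range from 9000 nM to 45000 nM, and it may well again return only a limit.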

Compound 4, half-maximal effective concentration: 8210 nM
The estimate for compound 4 lay 2.4-fold (0.39 log units) above the measured number, outside the stated range (below it).
By their numbers in this assay, from the lowest: compound 4; then compounds 1 and 3 (each within the scatter of the next). At a limit, above all of these: compound 2.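

Going by these compounds alone, the group on the amide-type nitrogen is not as unimportant in this assay as the earlier compounds suggested: 4-nitrophenyl in place of naphthalen-1-yl gave a 2.1-fold lower number from compound 1 to compound 4 (0.33 log units; beyond the scatter), and 4-nitrophenyl in place of cyclohexyl gave a 2.1-fold lower number from compound 3 to compound 4 (0.33 log units; beyond the scatter). The cleanest comparison is the one that differs by a single substituent, nitro in place of hydrogen on an aromatic carbon, which gave an at least 2.4-fold lower number from compound 2 to compound 4 (0.38 log units; beyond the scatter), a modest step that ties the change to the nitro group on that ring rather than to the swap of ring type. This step has only a floor, since compound 2 returned a limit and not a number: the limit of > 20000 nM in this assay, at which 1 of the 4 values shown sits.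

Compound 4 is the only compound shown with a substituent on this phenyl ring, so one result cannot tell whether the nitro group is special or whether other groups there would lower the number as well. Going by these compounds, an amine, a carboxylic acid or a methoxy group in the same place would begin to settle this, and whether a larger step can be reached at this position stays open.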